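Acyl Variation and Cytotoxicity on Vero Cells

The compounds below may be only part of what the source reports. "The series", "measured", "known", "first", "only" and "open" are said of these compounds alone.

Three measured compounds share one core and differ only in the group on the carbonyl carbon. Compound 1 `CC(C)(C)C(=O)N1CCN(c2nc(=O)c3cc(C(F)(F)F)cc([N+](=O)[O-])c3s2)CC1` carries tert-butyl there; in an ADME assay on Vero cells (Chlorocebus sabaeus) for cytotoxicity, read by MTT assay, with a stated time of 72 h (on this read-out higher numbers stand for lower toxicity in this test and lower numbers for higher toxicity in this test), compound 1 gives only a limit, > 125000 nM. Compound 2 `O=C(C1CCCCC1)N1CCN(c2nc(=O)c3cc(C(F)(F)F)cc([N+](=O)[O-])c3s2)CC1` carries cyclohexyl, and in this assay compound 2 gives 88700 nM. Compound 3 `O=C(C1CCCC1)N1CCN(c2nc(=O)c3cc(C(F)(F)F)cc([N+](=O)[O-])c3s2)CC1` carries cyclopentyl, and in this assay compound 3 gives 120000 nM, the higher of the two numbers shown, though the gap to compound 2 is within the scatter. The steps of an at least 1.4-fold lower number from compound 1 to compound 2 (0.14 log units; that floor lies within the scatter) and an at least 1.0-fold lower number from compound 1 to compound 3 (0.01 log units; that floor lies within the scatter) start from a limit, and a 1.4-fold higher number from compound 2 to compound 3 (0.13 log units; within the scatter) is within the scatter, so the three values show no change beyond the scatter. Compound 4 `CC(C)(C)C1CCC(C(=O)N2CCN(c3nc(=O)c4cc(C(F)(F)F)cc([N+](=O)[O-])c4s3)CC2)CC1` continues the series: 4-(tert-butyl)cyclohexyl in place of cyclopentyl on a carbonyl carbon. With a 1.4-fold higher number from compound 2 to compound 3 (0.13 log units; within the scatter) within the scatter, the step from compound 3 to compound 4 is expected to be a 1.6-fold lower number from compound 3 to compound 4 (0.20 log units; within the scatter), no change beyond the scatter. Compound 4 is therefore estimated at 75000 nM, between 30000 nM and 125000 nM.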

Compound 4, half-maximal cytotoxic concentration: > 125000 nM
Compound 4: no number, only a limit; the forecaster's own chance of this, stated with the estimate: 25%; middle value at least 1.6-fold (0.22 log units) away from the limit.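

In this assay compound 4 gives only a limit, as compound 1 does: the limit of > 125000 nM in this assay, at which 2 of the 4 values shown sit.

Placing tert-butyl on a saturated ring carbon of the cyclohexyl group gives an at least 1.4-fold higher number from compound 2 to compound 4 (0.14 log units; that floor lies within the scatter), and the change from cyclopentyl to 4-(tert-butyl)cyclohexyl gives an at least 1.0-fold higher number from compound 3 to compound 4 (0.01 log units; that floor lies within the scatter). Both floors lie within the scatter, but they show that this position on the carbonyl carbon can carry a group of 10 heavy atoms, against 5 in cyclopentyl, without a lower number in this test. The step between compound 1 and compound 4 cannot be read, since both values are limits.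

The compounds shown leave open how far compound 1 and compound 4 lie past the limit. They also leave open whether an amine, a carboxylic acid or a phenyl ring at this position would keep the number at this level.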